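Cytotoxicity notes: benzyl in place of 4-aminophenyl

This account rests on a few compounds, and the source may have more. Where it says the series, first, only, none or still open, it means among the compounds named here.

Measured so far:
compound 1 `Cc1ccccc1-c1nn(-c2ccc(N)cc2)cc1CNCCN1CCN(C)CC1` — > 20000 nM
compound 2 `CN1CCN(CCNCc2cn(-c3ccc(F)cc3F)nc2-c2ccc(N(C)C)cc2)CC1` — > 20000 nM

In an ADME assay on Huh-7 cells (Homo sapiens) for cytotoxicity (on this read-out higher numbers stand for lower toxicity in this test and lower numbers for higher toxicity in this test), compound 1 gives > 20000 nM. This is a limit of the test, not a number. Compound 2 gives > 20000 nM in this assay. That value is likewise a limit. Compound 1 therefore stands at the same limit as the other measured compound (the limit of > 20000 nM in this assay, at which 2 of the 2 values shown sit), and no order between the two can be read. Going by the values given here, no step between measured compounds that differ in a single place is available, so the size of the change studied here has no measured precedent.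

Compound 3 `Cc1ccccc1-c1nn(Cc2ccccc2)cc1CNCCN1CCN(C)CC1` differs from compound 1 by benzyl in place of 4-aminophenyl on an aromatic nitrogen.

In this assay no movement beyond the usual scatter is expected, given that both measured compounds sit at the limit (the limit of > 20000 nM in this assay, at which 2 of the 2 values shown sit). Compound 3 is expected to give 20000 nM, with a range of 8000 nM to 50000 nM. The expected step of a number no higher from compound 1 to compound 3 (the limit leaves the size open) is most likely to return a limit again rather than a number.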

Compound 3, half-maximal cytotoxic concentration: > 20000 nM
Compound 3: only a limit was reported; the forecaster's own chance of this, stated with the estimate: 70%; the middle value sits exactly at the limit.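

In this assay compound 3 gives > 20000 nM, a limit and not a number. The step between compound 1 and compound 3 cannot be read: the limit of > 20000 nM in this assay, at which 3 of the 3 values shown sit. The compounds shown leave open whether benzyl and 4-aminophenyl on the aromatic nitrogen differ at all in this assay.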